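The compounds below may be only part of what the source reports. "The series", "measured", "known", "first", "only" and "open" are said of these compounds alone.

Measured so far in a functional assay on the whole organism for inhibition, with Rattus norvegicus as the target; on this read-out higher numbers stand for an effect only at larger amounts of compound and lower numbers for an effect already at smaller amounts:
compound 1, `N#Cc1cccnc1N1CCN(CCCCN2C(=O)SC3(CCCC3)C2=O)CC1`, 29.3 mg/kg
compound 2, `O=C1SC2(CCCC2)C(=O)N1CCCCN1CCN(c2ncccc2-c2ccccc2)CC1`, a limit of the assay, > 100 mg/kg
compound 3, `COC(=O)c1cccnc1N1CCN(CCCCN2C(=O)SC3(CCCC3)C2=O)CC1`, 50.2 mg/kg

Compound 3 gives the highest of the two numbers in this assay; compound 1 comes nearest, and the gap a 1.7-fold higher number from compound 1 to compound 3 (0.23 log units; within the scatter) lies within the scatter. The value of compound 2 is a limit of the assay, not a number. Hence an at least 1.9-fold lower number from compound 2 to compound 3 (0.29 log units; that floor lies within the scatter) has only a floor.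

Compound 4, `O=C1SC2(CCCC2)C(=O)N1CCCCN1CCN(c2ncccc2Cl)CC1`, is the next step from compound 3. The change is chloro in place of methoxycarbonyl on an aromatic carbon. Of the measured steps, a 1.7-fold higher number from compound 1 to compound 3 (0.23 log units; within the scatter) bears most on it: exchanging cyano for methoxycarbonyl on that aromatic carbon moved the number within the scatter, and chloro, like cyano, is a group of few heavy atoms bringing no hydrogen-bond acceptors. The step of an at least 3.4-fold higher number from compound 1 to compound 2 (0.53 log units; beyond the scatter) shows that phenyl in that place pushed the value to the limit (the limit of > 100 mg/kg in this assay, at which 1 of the 3 values shown sits); chloro is far from phenyl in what is counted. So no step beyond the scatter is expected, with a lean toward a lower number. For compound 4 the estimate is 35 mg/kg, range 15 mg/kg to 90 mg/kg. This corresponds to an expected step of a 1.4-fold lower number from compound 3 to compound 4 (0.16 log units; within the scatter).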

Compound 4, dose for half-maximal effect: 50 mg/kg
Compound 4: the middle estimate sits 1.4-fold (0.15 log units) below what was measured; the measured number falls inside the stated range.
By their numbers in this assay, from the lowest: compounds 1, 4 and 3 (each within the scatter of the next). At a limit, above all of these: compound 2.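

In this assay, chloro in place of methoxycarbonyl on this aromatic carbon, two atoms from the ring nitrogen, gives a 1.0-fold lower number from compound 3 to compound 4 (0.00 log units; within the scatter), so a group with 0 hydrogen-bond acceptors is not told apart from one with 2. The step of a 1.7-fold higher number from compound 1 to compound 4 (0.23 log units; within the scatter) reads the same way, which leaves cyano, methoxycarbonyl and chloro all within the scatter of one another at this place. The value of compound 2 remains a limit of the assay, and the step of an at least 2.0-fold lower number from compound 2 to compound 4 (0.30 log units; that floor lies within the scatter) offers only a floor, so chloro and phenyl are not separated by a readable size.

Open, as far as these compounds go, is whether an amine or a carboxylic acid on this aromatic carbon would stay within the same scatter. Also open, from the compounds shown here alone, is how a longer chain between the two ends of the core would change the number.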